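Compound 1 to compound 4: loss of the (furan-2-yl)carbonyl

A few compounds are considered here, and "the series" means these few. Any claim that something is new, unique, unknown or untested is made for them only; others in the source may bear on it.

Measured in an ADME assay on Chem1 cells (Homo sapiens) for cytotoxicity; on this read-out lower numbers stand for higher toxicity in this test and higher numbers for lower toxicity in this test:
compound 1 `NCCCCN(C[C@@H]1CN(C(=O)c2ccco2)CCN1)[C@H]1CCCc2cccnc21`: > 10 uM
compound 2 `NCCCCN(C[C@H]1CN(S(=O)(=O)c2ccc(Cl)cc2)CCN1)[C@H]1CCCc2cccnc21`: > 10 uM
compound 3 `NCCCCN(C[C@H]1CN(C(=O)Nc2ccccc2)CCN1)[C@H]1CCCc2cccnc21`: > 10 uM

All three entries are limits and not numbers. Compound 1 stands at the limit of > 10 uM. Compound 2 and compound 3 are limits too, so compound 1 has no readable rank among them.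

Compound 4 `NCCCCN(C[C@@H]1CNCCN1)[C@H]1CCCc2cccnc21` is not yet measured and differs from compound 1 in one place: hydrogen in place of (furan-2-yl)carbonyl on an amine nitrogen in a ring. It carries hydrogen in place of (furan-2-yl)carbonyl on an amine nitrogen in a ring.

For the measured compounds named here, the only measured step is a step that the two limits leave unreadable from compound 2 to compound 3, and it gives no size. The one firm feature of the series is the limit of > 10 uM in this assay, at which 3 of the 3 values shown sit. Going by the values given here, no measured compound goes against this, but each one carries a group on that ring nitrogen, so no measured step covers the bare nitrogen of compound 4.

Compound 1 therefore offers only a limit as a starting point, and with a step that the two limits leave unreadable from compound 2 to compound 3 unreadable, no step beyond the scatter is expected in this assay. The expected step is a step that the limit leaves unreadable from compound 1 to compound 4. The estimate for compound 4 is 20 uM, with an expected range from 8 uM to 50 uM.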

Compound 4, half-maximal toxic concentration: > 10 uM
Compound 4: no number, only a limit; the forecaster's own chance of this, stated with the estimate: 80%; the middle value lies beyond the limit too.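

In this assay, compound 1 and compound 4 each give only a limit and not a number, so no step can be read for hydrogen in place of (furan-2-yl)carbonyl. The compounds shown leave open how far any of them lies beyond that limit, and whether this change on the ring nitrogen has any effect on the read-out.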